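Chloro substitution and a toxicity limit in a small series

This account rests on a few compounds, and the source may have more. Where it says the series, first, only, none or still open, it means among the compounds named here.

Compound 1 `Cn1c(-c2ccccc2)cnc1NC(=O)c1ccc(F)cc1` is the parent of this set. In a toxicity assay on THP-1 cells (Homo sapiens) for inhibition (a lower number here means that less compound is tolerated, a higher number that more compound is tolerated), compound 1 gives > 100000 nM, a value that is a limit of the assay and not a number. Compound 2 `Cn1c(-c2ccc(Cl)cc2)cnc1NC(=O)c1ccc(F)cc1` differs from it by chloro in place of hydrogen on an aromatic carbon, and in this assay compound 2 gives 37000 nM, which makes an at least 2.7-fold lower number from compound 1 to compound 2 (0.43 log units; beyond the scatter). Compound 3 `Cn1c(-c2ccccc2)cnc1NC(=O)c1ncc[nH]1` differs from compound 1 by 1H-imidazol-2-yl in place of 4-fluorophenyl on a carbonyl carbon. In this assay compound 3 gives > 100000 nM, again a limit of the assay and not a number. Because of that, a step that the two limits leave unreadable from compound 1 to compound 3, as the limit of > 100000 nM in this assay, at which 2 of the 3 values shown sit, shows.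

Compound 4 `Cn1c(-c2cccc(Cl)c2)cnc1NC(=O)c1ncc[nH]1` is the unmeasured member. It differs from compound 3 by chloro in place of hydrogen on an aromatic carbon. Among the compounds with values here, this is the same kind of change as the one from compound 1 to compound 2, though there the chloro entered para to a large group and here it enters meta to a large group. Since the measured change gave an at least 2.7-fold lower number from compound 1 to compound 2 (0.43 log units; beyond the scatter), compound 4 is expected to show an at least 2.0-fold lower number from compound 3 to compound 4 (0.30 log units; that floor lies within the scatter). The estimate for compound 4 in this assay is 50000 nM, with a range from 20000 nM to 150000 nM.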

Compound 4, half-maximal cytotoxic concentration: 55000 nM
The estimate for compound 4 lay 1.1-fold (0.04 log units) below the measured number, within the range that was stated.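

In this assay, chloro in place of hydrogen on an aromatic carbon again goes with a lower number on the second core, with an at least 1.8-fold lower number from compound 3 to compound 4 (0.25 log units; that floor lies within the scatter) for this change of phenyl to 3-chlorophenyl. Compound 3 gives > 100000 nM, which is a limit of the assay and not a number, so this pair fixes no true size for the step. The direction therefore carries from one core to the other in these two pairs, but equal size is not shown, and the chloro does not stand in the same place on the phenyl ring in the two pairs: the same change on two cores in this assay, an at least 2.7-fold lower number (0.43 log units; beyond the scatter) from compound 1 to compound 2 and an at least 1.8-fold lower number (0.25 log units; that floor lies within the scatter) from compound 3 to compound 4; the limit leaves it open whether they differ.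

The compounds shown leave open whether a 3-chlorophenyl group on the core of compound 1 would give a step like the one on the core of compound 3, and whether the chloro's place matters at all. They also leave open how a methoxy group, an amine or a carboxylic acid in place of the chloro would read in this assay on either core.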